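The source may hold more compounds than are shown below. What is called first, only, known or untested is meant among the compounds shown, and "the series" means these compounds.

Compound 1 `COc1ccc(C(=O)/C=C/c2ccc(N(C)C)cc2)c2c1C=CC(C)(C)O2` carries a 4-(dimethylamino)phenyl group on the double-bonded chain of its core. In a functional assay on SW-620 cells (Homo sapiens) for antiproliferative activity, read by MTT assay, with a stated time of 24 h (on this read-out higher numbers stand for weaker inhibition and lower numbers for stronger inhibition), compound 1 gives 570 nM, the lowest of the three numbers measured. Compound 2 `COc1ccc(C(=O)/C=C/c2ccc3ccccc3c2)c2c1C=CC(C)(C)O2` gives 2140 nM in this assay, and compound 3 `COc1ccc(C(=O)/C=C/c2ccc(N3CCCC3)cc2)c2c1C=CC(C)(C)O2` gives 7150 nM. For the measured compounds named here, the one change measured at the aromatic substituent, a 13-fold higher number from compound 1 to compound 3 (1.10 log units; beyond the scatter), is a large step toward weaker inhibition. Compound 4 `COc1ccc(C(=O)/C=C/c2ccc(Cl)c(Cl)c2)c2c1C=CC(C)(C)O2` has not yet been measured; it differs from compound 1 by 3,4-dichlorophenyl in place of 4-(dimethylamino)phenyl on a double-bonded chain carbon bound to a double-bonded chain carbon. Going by the values given here, no measured step replaces the dimethylamino group with chlorine, so the change is only partly covered by the data. What is known is that both departures from compound 1, to compound 2 and to compound 3, gave higher numbers in this assay. An increase beyond the scatter is therefore expected, though smaller than the step to compound 3 seems the more cautious reading. Compound 4 is expected to give about 2500 nM in this assay, within a range from 700 nM to 9000 nM. That estimate amounts to an expected 4.4-fold higher number from compound 1 to compound 4 (0.64 log units; beyond the scatter).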

Compound 4, half-maximal inhibitory concentration: 7700 nM
The estimate for compound 4 lay 3.1-fold (0.49 log units) below the measured number; measured number inside the range.
By their numbers in this assay, from the lowest: compound 1; then compound 2; then compounds 3 and 4 (each within the scatter of the next).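

In this assay, 3,4-dichlorophenyl in place of 4-(dimethylamino)phenyl on a double-bonded chain carbon bound to a double-bonded chain carbon gives a 14-fold higher number from compound 1 to compound 4 (1.13 log units; beyond the scatter), a large step toward weaker inhibition. The earlier large step, a 13-fold higher number from compound 1 to compound 3 (1.10 log units; beyond the scatter), kept a nitrogen on the aromatic ring, whereas this one replaces the whole aromatic group with a chlorine-bearing one, yet compounds 3 and 4 lie within the scatter of each other, so very different groups at this position can end at similar numbers. No measurement here explains the loss seen with either change.

As far as these compounds go, it remains open whether a single chlorine at the same place would behave like the 3,4-dichlorophenyl group. Also open, from the compounds shown here alone, is whether a 4-(diethylamino)phenyl or 4-methoxyphenyl group would stay near compound 1 or move toward compounds 3 and 4.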